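Compound 3 to compound 4: methyl to trifluoromethyl

The compounds below may be only part of what the source reports. "The series", "measured", "known", "first", "only" and "open" are said of these compounds alone.

In a functional assay on A549 cells (Homo sapiens) for antiproliferative activity, read by MTT assay, with a stated time of 24 h (a higher number here means a weaker inhibitor, a lower number a stronger inhibitor), compound 1 (`Cc1ccc(-c2nn(-c3ccccc3)cc2-c2nc3ccccc3n2S(=O)(=O)c2ccc(C)cc2)cc1`) reads 460 nM and compound 2 (`Cc1ccc(-c2nn(-c3ccccc3)cc2-c2nc3ccccc3n2S(=O)(=O)c2cc(C)ccc2C)cc1`) reads 270 nM with the gap between them (a 1.7-fold lower number from compound 1 to compound 2 (0.23 log units; within the scatter)) inside the scatter. Compound 3 (`Cc1ccc(-c2nn(-c3ccccc3)cc2-c2nc3ccccc3n2S(=O)(=O)c2ccc(Cl)cc2)cc1`) reads 3550 nM and is the weakest of the three (a 7.7-fold higher number from compound 1 to compound 3 (0.89 log units; beyond the scatter) and a 13-fold higher number from compound 2 to compound 3 (1.12 log units; beyond the scatter)).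

Compound 4 (`O=S(=O)(c1ccc(Cl)cc1)n1c(-c2cn(-c3ccccc3)nc2-c2ccc(C(F)(F)F)cc2)nc2ccccc21`) keeps the 4-chlorophenyl on the sulfonyl sulfur of compound 3 and carries trifluoromethyl in place of methyl on an aromatic carbon so that 4-methylphenyl becomes 4-(trifluoromethyl)phenyl. Within the data shown here, no measured step changes this group. All three measured steps lie on the sulfonyl side. The closest in kind is the modest chloro-for-methyl swap (a 7.7-fold higher number from compound 1 to compound 3 (0.89 log units; beyond the scatter)) but it sits at another place and gives no direction here. No step beyond the scatter is therefore expected from this change. The estimated step is a 1.1-fold higher number from compound 3 to compound 4 (0.05 log units; within the scatter) and it remains loosely supported. For compound 4 the expected value is 4000 nM with an estimated range of 1200 nM to 12000 nM in this assay pending measurement.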

Compound 4, half-maximal inhibitory concentration: 2560 nM
Estimate against measurement, compound 4: 1.6-fold (0.19 log units) above, and the stated range covers the measured number.
By their numbers in this assay, from the lowest: compounds 2 and 1 (each within the scatter of the next); then compounds 4 and 3 (each within the scatter of the next).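

In this assay, among these compounds, the one step on the 4-methylphenyl side of the molecule is a 1.4-fold lower number from compound 3 to compound 4 (0.14 log units; within the scatter), so trifluoromethyl and methyl on this aromatic carbon, para to a large group, cannot be told apart when 4-chlorophenyl sits on the sulfonyl sulfur. Two of the three earlier steps, all on the sulfonyl side, lie beyond the scatter, whereas this position accepts four heavy atoms in place of one without a step beyond it in this pair. Nothing available explains this result or links it to any measured property of the two groups.

As far as these compounds go, whether the same holds with 4-methylphenyl or 2,5-dimethylphenyl on the sulfonyl sulfur remains open, since a single pair cannot show it. Also open, from the compounds shown here alone, is how this place responds to quite different groups, such as an amine, a carboxylic acid or a longer alkyl chain.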